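A few compounds are considered here, and "the series" means these few. Any claim that something is new, unique, unknown or untested is made for them only; others in the source may bear on it.

Working notes on the series. Compound 1 `Oc1ccccc1CNc1ccc(-c2ccc(F)cc2)cc1` and compound 2 `Oc1ccccc1CNc1ccc(-c2ccc(Cl)cc2)cc1` share one core; compound 2 differs from compound 1 by chloro in place of fluoro on an aromatic carbon. In a functional assay on Jurkat cells (Homo sapiens) for activation, with a stated time of 24 h (on this read-out higher numbers stand for an effect only at larger amounts of compound and lower numbers for an effect already at smaller amounts), compound 1 gives 3860 nM. In this assay compound 2 gives 2390 nM; the step is a 1.6-fold lower number from compound 1 to compound 2 (0.21 log units; within the scatter), so the two are not separated by this read-out.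

Compound 3 `Oc1ccccc1CNc1ccc(-c2ccc(F)cc2)nc1` is built on a second core; the difference between the two cores is not broken down here. In this assay compound 3 gives 2590 nM, a number that sits within the scatter of both compound 1 and compound 2, so no order among the three measured compounds can be drawn.

Compound 4 `Oc1ccccc1CNc1ccc(-c2ccc(Cl)cc2)nc1` has not yet been measured. It differs from compound 3 by chloro in place of fluoro on an aromatic carbon, the same change, made at the same kind of place, as the one from compound 1 to compound 2; among the compounds shown it occurs two times in all.

Going by the values given here, for compound 4 a step of a 1.5-fold lower number from compound 3 to compound 4 (0.18 log units; within the scatter) is expected in this assay, because the single earlier instance of this change gave a 1.6-fold lower number from compound 1 to compound 2 (0.21 log units; within the scatter) and nothing in the measured compounds suggests the second core would behave otherwise. On this basis compound 4 is estimated at 1700 nM, with a plausible range from 800 nM to 3600 nM. The measurement will show whether the modest shift seen on the first core carries over.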

Compound 4, half-maximal effective concentration: "not active" (no number reported)
Compound 4 has no reported number here, so the estimate cannot be set against anything.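

In this assay, going by these compounds alone, compound 4 is reported as not active, with no number, so no step from compound 3 to compound 4 can be read. The compounds shown leave open whether the change from 4-fluorophenyl to 4-chlorophenyl behaves differently on the core of compound 3 than on the core of compound 1. Nothing in the data shown offers an explanation for this result.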